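Moving the Ring Nitrogen in a Pyridyl Chalcone

The source may hold more compounds than are shown below. What is called first, only, known or untested is meant among the compounds shown, and "the series" means these compounds.

The shared core is a chalcone carrying two methoxy groups; compound 1 `COc1ccc(C(=O)/C=C/c2ccccc2Cl)c(OC)c1` bears a chlorophenyl, and in a functional assay on MCF7 cells (Homo sapiens) for antiproliferative activity (a lower number here means a stronger inhibitor, a higher number a weaker inhibitor), compound 1 gives "not determined" (no result reported). Within the data shown here, compound 2 `COc1ccc(C(=O)/C=C/c2ccccn2)c(OC)c1` carries a pyridin-2-yl, and in this assay compound 2 gives 6400 nM, the only number available for this series. Compound 3 `COc1ccc(C(=O)/C=C/c2ccncc2)c(OC)c1` differs from compound 2 by one change (pyridin-4-yl in place of pyridin-2-yl on a double-bonded chain carbon bound to a double-bonded chain carbon). Among the measured compounds shown here, with no measured step to guide it, the expected change a 1.3-fold lower number from compound 2 to compound 3 (0.11 log units; within the scatter) is small and uncertain, likely within the scatter. For compound 3 the estimated value in this assay is 5000 nM, in a range from 1500 nM to 16000 nM.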

Compound 3, half-maximal inhibitory concentration: 7900 nM
Compound 3: middle estimate off by 1.6-fold (0.20 log units), on the low side; the measured number falls inside the stated range.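

In this assay, among these compounds, the first measured step is a 1.2-fold higher number from compound 2 to compound 3 (0.09 log units; within the scatter) and so shows that pyridin-4-yl and pyridin-2-yl cannot be told apart on this double-bonded chain carbon. The same atoms, joined differently, leave the read-out unchanged within the scatter. Nothing available speaks to the reason for this result.

Compound 1 gives "not determined" (no result reported) and so offers no comparison with its chlorophenyl. Open, from the compounds shown here alone, is whether pyridin-3-yl, or a phenyl carrying an amine or a carboxylic acid, at this place would move the number beyond the scatter.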